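This account rests on a few compounds, and the source may have more. Where it says the series, first, only, none or still open, it means among the compounds named here.

Compound 1 `CCc1ccccc1NC(=O)N[C@H](C)c1ccccc1` gives 100% in an ADME assay on the whole organism with Oryza sativa as the target, tested at 1 uM; on this read-out lower numbers stand for a stronger effect and higher numbers for a weaker effect at the one concentration tested.
Compound 2 `C[C@@H](NC(=O)Nc1ccccc1Cl)c1ccccc1` gives 103% in this assay.

Among the measured compounds shown here, compound 2 stands highest of the two numbers, with compound 1 as its nearest neighbour; the one measured step, a number 3 percentage points higher from compound 1 to compound 2 (within the scatter), came with chloro in place of ethyl on an aromatic carbon and does not reach beyond the scatter. Compound 3 `C[C@@H](NC(=O)Nc1ccccc1Br)c1ccccc1` differs from compound 2 by bromo in place of chloro on an aromatic carbon. For the measured compounds named here, no measured step exchanges one halogen for another, and the single step available was within the scatter, so compound 3 is expected to show a number 2 percentage points lower from compound 2 to compound 3 (within the scatter), no change beyond the scatter. Compound 3 is therefore estimated at 101%, between 91% and 111%.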

Compound 3, a percentage reported as activity, at one concentration (the size of the read-out at that concentration, not a potency): 100%
Compound 3: middle estimate off by 1 percentage points, on the high side, within the range that was stated.
By their numbers in this assay, from the lowest: compounds 1, 3 and 2 (each within the scatter of the next).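

In this assay, bromo in place of chloro on an aromatic carbon, ortho to a large group, gives a number 3 percentage points lower from compound 2 to compound 3 (within the scatter) and bromo in place of ethyl gives no change at the digits printed from compound 1 to compound 3 (within the scatter) at the same place. Among the compounds shown here, this adds the first exchange of one halogen for another, and ethyl, chloro and bromo at this place cannot be told apart on this read-out. Nothing available explains this result.

On these data alone, whether an amine, a carboxylic acid or a methoxy group at this place would shift the number beyond the scatter remains open. So does whether any change elsewhere on the core of compound 3 would do so.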